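The source may report more compounds than this note shows. Statements on the series, on what has been measured and on what is new or still open speak of the compounds shown alone.

Compound 1 `O=C(O)/C(S)=C/c1c[nH]c2ccc(F)cc12` and compound 2 `O=C(O)/C(S)=C/c1c[nH]c2cc(F)ccc12` are built from the same atoms joined differently; how the two cores differ is not broken down here. In an assay on isolated protein for inhibition of Calpain-1 catalytic subunit (Sus scrofa), read by FRET (a lower number here means a stronger inhibitor, a higher number a weaker inhibitor), compound 2 gives 10 nM, while compound 1 gives 800 nM, the highest number of the three measured compounds. Compound 3 `O=C(O)/C(S)=C/c1c[nH]c2cc(I)ccc12` carries iodo in place of fluoro on an aromatic carbon and gives 170 nM in this assay, a step of a 17-fold higher number from compound 2 to compound 3 (1.23 log units; beyond the scatter).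

Compound 4 `O=C(O)/C(S)=C/c1c[nH]c2ccc(I)cc12` is not yet measured. It stands to compound 1 as compound 3 stands to compound 2: the change is iodo in place of fluoro on an aromatic carbon, the same change as between compound 2 and compound 3, since the surroundings of the place are described in the same words. Going by the values given here, the only guide is the single measured step, which is a 17-fold higher number from compound 2 to compound 3 (1.23 log units; beyond the scatter). On that basis a step of about a 7.5-fold higher number from compound 1 to compound 4 (0.88 log units; beyond the scatter) is expected from compound 1 to compound 4 in this assay, though with one example the size is uncertain and a step of this size on the already weak compound 1 may push the number toward the range where only a limit is reported. The expected value for compound 4 in this assay is 6000 nM, estimated to lie between 1500 nM and 25000 nM.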

Compound 4, half-maximal inhibitory concentration: 100 nM
Beside the measured number, compound 4's estimate is 60-fold (1.78 log units) above it; the whole stated range lies above it.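

In this assay, iodo in place of fluoro does not act alike on the two cores, as the new step is an 8.0-fold lower number from compound 1 to compound 4 (0.90 log units; beyond the scatter), opposite in direction to the earlier one and clearly different from it: the same change on two cores in this assay, a 17-fold higher number (1.23 log units; beyond the scatter) from compound 2 to compound 3 and an 8.0-fold lower number (0.90 log units; beyond the scatter) from compound 1 to compound 4, 140-fold (2.13 log units) apart, beyond the scatter of two such steps

A step measured on one of these cores therefore could not be carried to the other, either in size or in direction. This rests on a single pair for each core, however, and it does not show why the two cores part, nor whether any other replacement of fluoro would part in the same way.

The compounds shown carry only fluoro or iodo at these places, so it remains open how chloro, bromo, methyl, a nitrile or an amine would behave on each core. From the compounds shown here alone, it is also open how either halogen compares with a plain hydrogen on the same core, which would show what each halogen does on its own core.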